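A few compounds are considered here, and "the series" means these few. Any claim that something is new, unique, unknown or untested is made for them only; others in the source may bear on it.

Working notes on the series. The shared core, seen in compound 1 `CCC(C)(C)Cc1c[nH]c(CCc2ccc(-n3cccn3)cc2)n1`, carries a five-membered heteroaryl on the distal benzene ring. In a functional assay on HEK293 cells for agonist activity at Bombesin receptor subtype-3 (Mus musculus), read by luminescence and calcium flux, with a stated time of 10 min (a higher number here means that more compound is needed for the effect, a lower number that less compound is needed), compound 1 gives 113 nM. Among the measured compounds shown here, compound 2 `CCC(C)(C)Cc1c[nH]c(CCc2ccc(-c3cnsc3)cc2)n1` replaces that group with 1,2-thiazol-4-yl; in this assay compound 2 gives 119 nM, the higher of the two numbers measured so far, with the step of a 1.1-fold higher number from compound 1 to compound 2 (0.02 log units; within the scatter) lying within the scatter. Compound 3 `CCC(C)(C)Cc1c[nH]c(CCc2ccc(-c3ccns3)cc2)n1` is the next member: 1,2-thiazol-5-yl in place of 1,2-thiazol-4-yl on an aromatic carbon. For the measured compounds named here, only one measured step bears on this change, the exchange of one heteroaryl for another at the same position, from compound 1 to compound 2, and it was within the scatter. A shift between two ring isomers of the same heteroaryl is therefore expected to stay within the scatter in this assay, with no direction favoured, which makes the step from compound 2 to compound 3 expected as a 1.0-fold higher number from compound 2 to compound 3 (0.00 log units; within the scatter). Compound 3 is estimated at 120 nM, with a range from 50 nM to 300 nM.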

Compound 3, half-maximal effective concentration: 103 nM
Beside the measured number, compound 3's estimate is 1.2-fold (0.07 log units) above it; low and high end bracket the measured number.
By their numbers in this assay, from the lowest: compounds 3, 1 and 2 (each within the scatter of the next).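

Exchanging the two ring isomers is now tested directly: in this assay the step is a 1.2-fold lower number from compound 2 to compound 3 (0.06 log units; within the scatter) and so 1,2-thiazol-4-yl and 1,2-thiazol-5-yl cannot be told apart at this place, on an aromatic carbon para to a large group. Among the compounds shown here, the exchange of 1H-pyrazol-1-yl for 1,2-thiazol-5-yl is a 1.1-fold lower number from compound 1 to compound 3 (0.04 log units; within the scatter) and so, where only one exchange had been read before, all three heteroaryl groups now read alike here. Nothing at hand accounts for this flat reading.

Going by these compounds, whether it extends beyond five-membered heteroaryls to a carboxylic acid, an amine or a pyridyl group at this place stays open. The compounds shown also leave open how a change elsewhere on the shared core would read.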